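Swapping the aryl group on the nitrogen: compound 2 to 3

The source may hold more compounds than are shown below. What is called first, only, known or untested is meant among the compounds shown, and "the series" means these compounds.

Measured in a functional assay on HCT-15 cells (Homo sapiens) for antiproliferative activity, read by MTT assay, with a stated time of 72 h; on this read-out lower numbers stand for stronger inhibition and higher numbers for weaker inhibition:
- compound 1 `COc1cc(-c2nccn2C)cc(OC)c1OC`: > 100000 nM (a limit of the assay)
- compound 2 `COc1cccc(-n2ccnc2-c2cc(OC)c(OC)c(OC)c2)c1`: 17100 nM

Among the measured compounds shown here, compound 2 holds the only actual number so far. Compound 1 gives only a limit, (the limit of > 100000 nM in this assay, at which 1 of the 2 values shown sits).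

Compound 3 `COc1cc(-c2nccn2-c2ccc(Br)cc2)cc(OC)c1OC` differs from compound 2 at one place: 4-bromophenyl in place of 3-methoxyphenyl on an aromatic nitrogen.

For the measured compounds named here, the sole measured step, an at least 5.8-fold lower number from compound 1 to compound 2 (0.76 log units; beyond the scatter), exchanged methyl for 3-methoxyphenyl, not one aryl group for another. It gives no direction here, though compound 3 keeps an aromatic ring on that nitrogen. No step beyond the scatter is therefore expected in this assay: the estimate is a 1.4-fold lower number from compound 2 to compound 3 (0.15 log units; within the scatter).

For compound 3 the expected value is 12000 nM, with an estimated range of 3000 nM to 50000 nM.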

Compound 3, half-maximal inhibitory concentration: 11700 nM
The estimate for compound 3 lay 1.0-fold (0.01 log units) above the measured number, and the stated range covers the measured number.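

In this assay, the exchange of one aryl group for another gives a 1.5-fold lower number from compound 2 to compound 3 (0.16 log units; within the scatter), so 3-methoxyphenyl and 4-bromophenyl on the aromatic nitrogen are not told apart. With an at least 8.5-fold lower number from compound 1 to compound 3 (0.93 log units; beyond the scatter), a second aryl group also gives a lower number than methyl, though only against a limit. Compound 1 gives a limit of the assay, not a number: the limit of > 100000 nM in this assay, at which 1 of the 3 values shown sits.

Open, as far as these compounds go, is whether 4-methoxyphenyl or 3-bromophenyl would separate the substituent from its place on the ring. Also open, from the compounds shown here alone, is whether benzyl, or a phenyl bearing an amine or a carboxylic acid, would stay at this level.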